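Taking one chloro off compound 2

The source may hold more compounds than are shown below. What is called first, only, known or untested is meant among the compounds shown, and "the series" means these compounds.

Compound 1 `Clc1cccc(Cl)c1C1=NC(c2ccccc2)CO1` gives 3.69
Compound 2 `Clc1cccc(C2=NC(c3ccccc3)CO2)c1Cl` gives 4.28

Only these two compounds have been measured so far, both in a physicochemical assay for lipophilicity; on this read-out lower numbers stand for lower lipophilicity and higher numbers for higher lipophilicity. Of the two numbers, compound 2 (4.28) stands highest, and compound 1 (3.69) lies lower by a gap beyond the scatter.

The account now turns to compound 3 `Clc1ccccc1C1=NC(c2ccccc2)CO1` which still awaits measurement. It departs from compound 2 by a single change hydrogen in place of chloro on an aromatic carbon with hydrogen in place of chloro on an aromatic carbon of a six-membered aromatic ring of carbon only, ortho to a chloro group and meta to a large group. The rest of the structure stays as it is.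

For the measured compounds named here, no measured pair here shows this exchange on its own, so the size of the step cannot be read from the data and remains a judgement. A fall beyond the scatter is expected in this assay and the estimated step is a number 0.63 log units lower from compound 2 to compound 3 (beyond the scatter) in size. Compound 3 is estimated at 3.65 with an expected range from 3.25 to 4.05 once the measurement is made.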

Compound 3, partition coefficient: 3.56
The estimate for compound 3 lay 0.09 log units above the measured number; the range from low to high includes it.
By their numbers in this assay, from the lowest: compounds 3 and 1 (each within the scatter of the next); then compound 2.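

In this assay, for the compounds shown here, putting hydrogen in place of the chloro that stands ortho to a chloro group and meta to a large group gives a number 0.72 log units lower from compound 2 to compound 3 (beyond the scatter), the first direct reading of what this exchange does at this position. The same kind of exchange, hydrogen in place of chloro on an aromatic carbon, gives a number 0.13 log units lower from compound 1 to compound 3 (within the scatter) when it starts from the other dichloro compound, so among these three compounds the size of the step depends on which chloro leaves, and only the exchange from compound 2 moves the number beyond the scatter. Nothing in the material at hand accounts for this difference between the two steps.

The compounds shown leave open how a methyl group, a methoxy group or an amine on that same aromatic carbon would read in this assay, since only chloro and hydrogen appear there. They also leave open whether the contrast between the two steps would recur on a core other than the one shared here.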